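The compounds below may be only part of what the source reports. "The series", "measured", "known", "first", "only" and "open" are said of these compounds alone.

Three compounds share one core, each carrying a different group on the sulfur-bearing side chain: compound 1 `CSCSCC1C2CCC(O2)C1C/C=C\CCCC(=O)O`, compound 2 `CCCCCCS(=O)(=O)CC1C2CCC(O2)C1C/C=C\CCCC(=O)O` and compound 3 `O=C(O)CCC/C=C\CC1C2CCC(O2)C1CSCCc1ccccc1`. In a functional assay on a cell-free system (plasma) for inhibition of thromboxane A2 receptor (Homo sapiens) (a higher number here means a weaker inhibitor, a lower number a stronger inhibitor), compound 1 gives 700 nM, compound 2 gives 25000 nM and compound 3 gives 5500 nM, so compound 3 stands second highest of the three, well below compound 2 and well above compound 1. Compound 4 `CCCCCCCCSCC1C2CCC(O2)C1C/C=C\CCCC(=O)O` differs from compound 3 by hexyl in place of phenyl on a saturated chain carbon, two bonds along the chain from a sulfur. For the measured compounds named here, the one measured step touching this side chain, a 7.9-fold higher number from compound 1 to compound 3 (0.90 log units; beyond the scatter), shows that enlarging the group there weakened inhibition modestly. Going by the values given here, compound 2, with a hexyl chain but a sulfone, shows the weakest number, yet no single-change step links it to compound 4. Compound 4 is therefore expected near compound 3, an estimated 1.4-fold lower number from compound 3 to compound 4 (0.14 log units; within the scatter), giving 4000 nM with a range from 1000 nM to 16000 nM.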

Compound 4, half-maximal inhibitory concentration: 547000 nM
Beside the measured number, compound 4's estimate is 140-fold (2.14 log units) below it, outside the stated range (above it).
By their numbers in this assay, from the lowest: compound 1; then compound 3; then compound 2; then compound 4.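

With six carbons on each side of the swap, replacing phenyl with hexyl in this assay still gives a 99-fold higher number from compound 3 to compound 4 (2.00 log units; beyond the scatter), so at this position a flat aromatic ring and an open chain of equal heavy-atom count are far from interchangeable. The longer reach from the small end of the series, a 780-fold higher number from compound 1 to compound 4 (2.89 log units; beyond the scatter), is far larger than a 7.9-fold higher number from compound 1 to compound 3 (0.90 log units; beyond the scatter), so the kind of group matters here as well as its length. No measurement here accounts for this loss of inhibition.

From the compounds shown here alone, whether a cyclohexyl ring in place of phenyl would behave like phenyl or like hexyl stays open. So does the effect of a shorter chain such as butyl.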